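A Phenyl Group Replaces the Ether Chain on the Core

The source may hold more compounds than are shown below. What is called first, only, known or untested is meant among the compounds shown, and "the series" means these compounds.

Measured compounds and their values:
compound 1 `Cc1nn(-c2ncnc3nc[nH]c23)c2c1C(OCc1ccc(Cl)cc1Cl)CC(=O)N2` gives 4 nM
compound 2 `Cc1cc(C)n(CCOC2CC(=O)Nc3c2c(C)nn3-c2ncnc3nc[nH]c23)n1` gives 16 nM
compound 3 `CCCCCCCCOC1CC(=O)Nc2c1c(C)nn2-c1ncnc2nc[nH]c12` gives 8 nM

These three share one core and differ only in the group attached through an oxygen on the saturated ring carbon. They were tested in a functional assay on HEK293 cells for agonist activity at G-protein coupled receptor 39 (Homo sapiens), read by scintillation proximity assay and inositol phosphate accumulation, with a stated time of 75 min, in the presence of a further agent that is not named here; on this read-out higher numbers stand for an effect only at larger amounts of compound and lower numbers for an effect already at smaller amounts. Compound 3 holds the second highest of the three numbers, yet both of its neighbours sit close: a 2.0-fold higher number from compound 1 to compound 3 (0.30 log units; within the scatter), and a 2.0-fold lower number from compound 2 to compound 3 (0.30 log units; within the scatter). For the measured compounds named here, the only step that reaches beyond the scatter is a 4.0-fold higher number from compound 1 to compound 2 (0.60 log units; beyond the scatter), which is still modest. Taken together, the measured steps say that swapping the tail beyond the oxygen moves the read-out little.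

Compound 4 `Cc1nn(-c2ncnc3nc[nH]c23)c2c1C(c1ccc(OC(C)C)cc1)CC(=O)N2` differs from compound 3 in another way: 4-isopropoxyphenyl in place of octyloxy on a saturated ring carbon. Here the oxygen that linked the tail to the core is gone and an aromatic ring sits directly on the saturated ring carbon. Going by the values given here, no measured step tests such a change, so the three recorded steps bear on it only loosely, by showing that the core tolerates different tails at this place. Because of a 4.0-fold higher number from compound 1 to compound 2 (0.60 log units; beyond the scatter) and a 2.0-fold higher number from compound 1 to compound 3 (0.30 log units; within the scatter) a step no larger than modest is expected, with the direction uncertain, expressed as a 2.5-fold higher number from compound 3 to compound 4 (0.40 log units; beyond the scatter). Compound 4 is therefore estimated at 20 nM, with a range from 5 nM to 80 nM.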

Compound 4, half-maximal effective concentration: 18 nM
For compound 4 the middle estimate is 1.1-fold (0.05 log units) above the measured one; the measured number falls inside the stated range.
By their numbers in this assay, from the lowest: compounds 1, 3, 2 and 4 (each within the scatter of the next, the first and the last beyond it).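

The oxygen that joined the tail to the saturated ring carbon is not required for an effect in this assay: compound 4, with 4-isopropoxyphenyl sitting directly on that carbon, still gives a nanomolar read-out, and the printed steps are modest or smaller (a 2.3-fold higher number from compound 3 to compound 4 (0.35 log units; beyond the scatter); a 1.1-fold higher number from compound 2 to compound 4 (0.05 log units; within the scatter)). The largest step is the one from the (2,4-dichlorobenzyl)oxy group (a 4.5-fold higher number from compound 1 to compound 4 (0.65 log units; beyond the scatter)), so this replacement does carry a modest cost against compound 1, while against the dimethylpyrazole ether of compound 2 it makes no difference beyond the scatter. Nothing available explains any of these steps.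

Each step removes the linking oxygen and brings in a new tail at once, so the two changes cannot be told apart, and a phenoxy group, which would keep the oxygen and add an aromatic ring, could begin to separate them. From the compounds shown here alone, it also remains open what a plain phenyl without the isopropoxy group would give at this place, and whether an amine or a carboxylic acid on that ring would keep the effect.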